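Compound 3: propyl in place of 4-(4-methylphenoxy)butyl

The compounds below may be only part of what the source reports. "The series", "measured", "known", "first", "only" and "open" are said of these compounds alone.

In a functional assay on HepG2 cells (Homo sapiens) for antiproliferative activity, read by MTT assay, with a stated time of 48 h (on this read-out higher numbers stand for weaker inhibition of growth and lower numbers for stronger inhibition of growth), compound 2 (`Cc1ccc(OCCCCN(Cc2ccc(C(=O)NO)cc2)c2ncc(-c3ccc(C)cc3)s2)cc1`) gives 11000 nM, within the scatter of compound 1 (`Cc1ccc(-c2cnc(N(CCCCOc3ccccc3)Cc3ccc(C(=O)NO)cc3)s2)cc1`) at 16600 nM. Compound 3 (`CCCN(Cc1ccc(C(=O)NO)cc1)c1ncc(-c2ccc(C)cc2)s1`) differs from compound 2 by hydrogen in place of (4-methylphenoxy)methyl on a saturated chain carbon, three bonds along the chain from a nitrogen on an aromatic ring. Going by the values given here, the only measured step, a 1.5-fold lower number from compound 1 to compound 2 (0.18 log units; within the scatter), is methyl in place of hydrogen on an aromatic carbon, and it leaves this chain intact. It therefore offers no measure of the change, so no shift beyond the scatter is expected in either direction, and the expected step is a 1.1-fold higher number from compound 2 to compound 3 (0.04 log units; within the scatter). Compound 3 is estimated at 12000 nM, with an expected range of 4000 nM to 40000 nM.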

Compound 3, concentration for 50% growth inhibition: 2550 nM
Compound 3: middle estimate off by 4.7-fold (0.67 log units), on the high side; the whole stated range lies above it.
By their numbers in this assay, from the lowest: compound 3; then compounds 2 and 1 (each within the scatter of the next).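

In this assay the change from 4-(4-methylphenoxy)butyl to propyl gives the first shift beyond the scatter, a 4.3-fold lower number from compound 2 to compound 3 (0.63 log units; beyond the scatter), and the matching loss of the phenoxymethyl end gives a 6.5-fold lower number from compound 1 to compound 3 (0.81 log units; beyond the scatter). This position therefore responds to change, and the aryl ether end of the chain is not needed for inhibition of growth here, with compound 3 giving the lowest number of the three. Nothing measured here explains the shift. 

As far as these compounds go, whether methyl or ethyl in place of propyl would lower the number further remains open, as does the effect of an amine or a carboxylic acid at the chain end.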